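A few compounds are considered here, and "the series" means these few. Any claim that something is new, unique, unknown or untested is made for them only; others in the source may bear on it.

Compound 1 `C[S+]([O-])c1c(F)c(N)c2c(=O)cc(-c3ccc(N)c(F)c3)oc2c1F` gives 2500 nM in a functional assay on MCF7 cells (Homo sapiens) for cytotoxicity, read by neutral red uptake, with a stated time of 3 days; a lower number here means a stronger inhibitor, a higher number a weaker inhibitor.
Compound 2 `Nc1ccc(-c2cc(=O)c3c(N)c(F)c(CO)c(F)c3o2)cc1F` gives 62 nM in this assay.
Compound 3 `CN(C)CC(=O)OCc1c(F)c(N)c2c(=O)cc(-c3ccc(N)c(F)c3)oc2c1F` gives 26 nM in this assay.

Compound 2 holds the second highest number of the three. Compound 3 is its nearest neighbour, with a 2.4-fold lower number from compound 2 to compound 3 (0.38 log units; beyond the scatter), and compound 1 stands furthest away, with a 40-fold lower number from compound 1 to compound 2 (1.61 log units; beyond the scatter). The unmeasured compound 4 `CN(C)CCC(=O)OCc1c(F)c(N)c2c(=O)cc(-c3ccc(N)c(F)c3)oc2c1F` differs from compound 2 in one place: (2-(dimethylamino)ethyl)carbonyl in place of hydrogen on an oxygen on a saturated carbon. Within the data shown here, the only measured step that bears directly on this change is a 2.4-fold lower number from compound 2 to compound 3 (0.38 log units; beyond the scatter), where a closely related group was attached at the same oxygen and the number fell modestly. The step from compound 1 to compound 2 changes a different group and says little about an ester on this oxygen. With one related step as guide, a modest fall beyond the scatter, in the same direction, is expected for compound 4, with the step estimated as a 2.1-fold lower number from compound 2 to compound 4 (0.32 log units; beyond the scatter). In this assay compound 4 is thus expected to give about 30 nM, estimated within a range from 12 nM to 80 nM.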

Compound 4, half-maximal inhibitory concentration: 19 nM
Compound 4: the middle estimate sits 1.6-fold (0.20 log units) above what was measured, within the range that was stated.
By their numbers in this assay, from the lowest: compounds 4 and 3 (each within the scatter of the next); then compound 2; then compound 1.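

In this assay, a second ester on this oxygen, the (2-(dimethylamino)ethyl)carbonyl group, also lowers the number relative to the free hydroxymethyl compound, a 3.3-fold lower number from compound 2 to compound 4 (0.51 log units; beyond the scatter), so the fall no longer rests on a single ester. Placing (dimethylamino)methyl in place of dimethylamino on the chain gives a 1.4-fold lower number from compound 3 to compound 4 (0.14 log units; within the scatter), which means these two esters cannot be told apart here and this small change in the chain is tolerated. The large gap to the compound carrying the sulfur-containing group on the aromatic carbon also extends to this ester, a 130-fold lower number from compound 1 to compound 4 (2.12 log units; beyond the scatter).

Nothing available explains why these esters give lower numbers than the free hydroxymethyl compound. From the compounds shown here alone, it also remains open whether the terminal amine matters, which a plain acetyl ester could test, and whether a longer chain would hold the same level.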